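The source may hold more compounds than are shown below. What is called first, only, known or untested is meant among the compounds shown, and "the series" means these compounds.

Measured in a functional assay on SGC-7901 cells (Homo sapiens) for antiproliferative activity, read by MTT assay, with a stated time of 24 h; a lower number here means a stronger inhibitor, a higher number a weaker inhibitor:
- compound 1 `O=C(NNc1cccc(Cl)c1)c1ccc(NS(=O)(=O)c2cnc(O)nc2O)cc1`: 11600 nM
- compound 2 `O=C(NNc1ccccc1F)c1cccc(NS(=O)(=O)c2cnc(O)nc2O)c1`: > 20000 nM, a limit
- compound 3 `Cc1ccc(C(=O)NNC(=O)c2ccc(NS(=O)(=O)c3cnc(O)nc3O)cc2)cc1`: > 20000 nM, a limit

For the measured compounds named here, compound 2 stands at the limit of > 20000 nM in this assay, at which 2 of the 3 values shown sit, so its place is known only as a limit, and no step from it can be sized exactly.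

Compound 4 `O=C(NNC(=O)c1ccccc1Cl)c1cccc(NS(=O)(=O)c2cnc(O)nc2O)c1` has (2-chlorophenyl)carbonyl in place of 2-fluorophenyl on an amine nitrogen of compound 2: (2-chlorophenyl)carbonyl in place of 2-fluorophenyl on an amine nitrogen.

Going by the values given here, one measured step bears on this change, as it also puts a phenylcarbonyl group in place of a phenyl group on an amine nitrogen: an at least 1.7-fold higher number from compound 1 to compound 3 (0.23 log units; that floor lies within the scatter). The ring substituents differ between the two exchanges, and this single step rests on a limit, so the support is thin. No step beyond the scatter is therefore expected in this assay, and no direction is favoured.

The expected change is a number no higher from compound 2 to compound 4 (the limit leaves the size open). The estimate for compound 4 is 20000 nM, with an expected range of 10000 nM to 40000 nM.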

Compound 4, half-maximal inhibitory concentration: 6070 nM
Compound 4: middle estimate off by 3.3-fold (0.52 log units), on the high side, outside the stated range (below it).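

In this assay, for the compounds shown here, (2-chlorophenyl)carbonyl in place of 2-fluorophenyl on an amine nitrogen gives the only step that is printed as beyond the scatter: an at least 3.2-fold lower number from compound 2 to compound 4 (0.51 log units; beyond the scatter). Going by these compounds alone, the one other exchange of a phenyl group for a phenylcarbonyl group at such a nitrogen, an at least 1.7-fold higher number from compound 1 to compound 3 (0.23 log units; that floor lies within the scatter), settled no direction, so a phenylcarbonyl group at this place does not by itself bring a higher number, and it can go with a lower one. The size of the new step is only a floor, and the true gap may be larger: the limit of > 20000 nM in this assay, at which 2 of the 4 values shown sit.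

Going by these compounds, compound 4 differs from compound 2 by both the carbonyl and the change from fluorine to chlorine, so the share of each in the step remains open, and a (2-fluorophenyl)carbonyl group on this nitrogen would separate them. On these data alone, how a non-aromatic group such as acetyl would read at this nitrogen also remains open.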